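Same atoms, joined differently, on the sulfonyl sulfur

A few compounds are considered here, and "the series" means these few. Any claim that something is new, unique, unknown or untested is made for them only; others in the source may bear on it.

Measured compounds:
- compound 1, `O=C1[C@@H](NS(=O)(=O)c2cc3ccc(Cl)nc3s2)CCN1Cc1cc2c[nH]ccc-2n1`: 51%
- compound 2, `O=C1[C@@H](NS(=O)(=O)c2cc3nc(Cl)ccc3s2)CCN1Cc1cc2c[nH]ccc-2n1`: 58%

Both compounds were tested in an assay on isolated protein for inhibition of coagulation factor X (Oryctolagus cuniculus), tested at 1 uM; on this read-out higher numbers stand for more inhibition at the one concentration tested (going by the name of the read-out) and lower numbers for less inhibition. Compound 1 gives 51% and compound 2 gives 58%. Compound 2 shows the higher of the two numbers, but the gap to compound 1 is small: the step of a number 7 percentage points higher from compound 1 to compound 2 (within the scatter) stays within the scatter of repeated measurements, so the two compounds cannot be told apart on this read-out.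

Compound 3, `O=C1[C@@H](NS(=O)(=O)c2cc3ccnc(Cl)c3s2)CCN1Cc1cc2c[nH]ccc-2n1`, has the same atoms as compound 2 but arranged differently in the group on the sulfonyl sulfur: a group of 10 heavy atoms (7 carbon, 1 nitrogen, 1 sulfur, 1 chlorine; one five-membered aromatic ring with 1 hetero atom, one six-membered aromatic ring with 1 hetero atom) in place of a group of 10 heavy atoms (7 carbon, 1 nitrogen, 1 sulfur, 1 chlorine; one five-membered aromatic ring with 1 hetero atom, one six-membered aromatic ring with 1 hetero atom), on a sulfonyl sulfur. Within the data shown here, this is the same kind of change as the one from compound 1 to compound 2, which produced no step beyond the scatter. Among the measured compounds shown here, only that one step bears on the question, and it gives no reason to expect a clear shift in either direction in this assay.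

Compound 3 is therefore expected to give about 54% in this assay, within a range from 35% to 72%. The expected step of a number 4 percentage points lower from compound 2 to compound 3 (within the scatter) is estimated to lie within the scatter.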

Compound 3, a percentage reported as inhibition, at one concentration (the size of the read-out at that concentration, not a potency): 25%
For compound 3 the middle estimate is 29 percentage points above the measured one; the measured number lies below the stated range.
By their numbers in this assay, from the lowest: compound 3; then compounds 1 and 2 (each within the scatter of the next).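

In this assay this position proves sensitive to how the atoms of the group on the sulfonyl sulfur are joined: the change to compound 3 gives a number 33 percentage points lower from compound 2 to compound 3 (beyond the scatter) and also a number 26 percentage points lower from compound 1 to compound 3 (beyond the scatter), whereas the earlier change of the same kind stayed within the scatter. The groups that leave and enter have the same counts of atoms, rings, hydrogen-bond donors and hydrogen-bond acceptors, so these counts cannot separate the compounds, and only the way the atoms are joined distinguishes them. Nothing measured here explains why this rearrangement lowers the number when the other did not.

The compounds shown leave open whether the chlorine contributes to the difference, which a version of compound 3 carrying a methyl group, a methoxy group or an amine in its place could help to test. Among these compounds, they also leave open how these compounds compare in potency, since each has only a single reading at one concentration.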